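The compounds below may be only part of what the source reports. "The series", "measured", "known", "first", "only" and "open" are said of these compounds alone.

Values in a functional assay on U-937 cells (Homo sapiens), read by cAMP accumulation (on this read-out higher numbers stand for an effect only at larger amounts of compound and lower numbers for an effect already at smaller amounts), so far:
- compound 1 `CCc1nn(C2CCCC2)c2c1CCN(c1cccc(OC)c1)C2=O` gives 330 nM
- compound 2 `CCc1nn(C2CCS(=O)(=O)C2)c2c1CCN(c1cccc(OC)c1)C2=O` gives 5270 nM
- compound 3 `CCc1nn(C2CCCC2)c2c1CCN(c1cccc(Cl)c1)C2=O` is not yet measured

Of the two numbers, compound 1 holds the lower one, at 330 nM in this series. The next change leads to compound 3: chloro in place of methoxy on an aromatic carbon with chloro in place of methoxy on an aromatic carbon, meta to a large group. Within the data shown here, the only measured step is a 16-fold higher number from compound 1 to compound 2 (1.20 log units; beyond the scatter) and it swaps the group on an aromatic nitrogen, so it does not touch this place and gives no direct guide to size. A modest step in this assay is therefore expected, with a slight lean to a higher number and the direction uncertain. The expected step is a 1.4-fold higher number from compound 1 to compound 3 (0.13 log units; within the scatter) by this estimate. For compound 3 the estimated value is 450 nM with an expected range from 150 nM to 1500 nM in this assay.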

Compound 3, half-maximal effective concentration: 41 nM
Beside the measured number, compound 3's estimate is 11-fold (1.04 log units) above it; the measured number lies below the stated range.
By their numbers in this assay, from the lowest: compound 3; then compound 1; then compound 2.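

In this assay, 3-chlorophenyl in place of 3-methoxyphenyl gives an 8.0-fold lower number from compound 1 to compound 3 (0.91 log units; beyond the scatter), which shows that the aromatic carbon meta to a large group is a place where the number moves beyond the scatter, something the earlier change on the aromatic nitrogen could not show. At this place, the lower number goes with chloro, which has one heavy atom and no hydrogen-bond acceptor, against methoxy, which has two heavy atoms and one acceptor, but this single pair cannot separate those differences from the identity of the group. Nothing available accounts for the size or direction of this step.

From the compounds shown here alone, it remains open whether fluoro, trifluoromethyl or an amine on the same carbon would follow chloro or methoxy. Also open, going by these compounds, is whether 3-chlorophenyl keeps its effect alongside 1,1-dioxothiolan-3-yl on the aromatic nitrogen.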